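The compounds below may be only part of what the source reports. "The series", "measured", "known", "first", "only" and "open" are said of these compounds alone.

Compound 1, `N=C(NCCCc1c[nH]cn1)NCCCC(c1ccccc1)c1ccccn1`, in a functional assay on ileum for antagonist activity at histamine H1 receptor (Cavia porcellus) (a higher number here means weaker binding, a lower number tighter binding), gives 251 nM.
Compound 2, `N=C(NCCCc1c[nH]cn1)NCCC(c1ccccc1)c1ccccn1`, in this assay gives 97.7 nM.
Compound 3, `COc1ccc(C(CC/N=C(\N)NCCCc2c[nH]cn2)c2ccccn2)cc1`, in this assay gives 269 nM.

Among these three, compound 2 has the lowest number, and so the tightest binding of the set. Compound 1 stands nearest to it yet still beyond the scatter, and compound 3 lies furthest away, also beyond the scatter. Compound 2 is therefore the reference point for the next step.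

Compound 4, `N=C(NCCCc1c[nH]cn1)NCCC(c1ccc(Cl)cc1)c1ccccn1`, is not yet measured in this assay. It differs from compound 2 in one place: chloro in place of hydrogen on an aromatic carbon. The chloro sits on an aromatic carbon of a six-membered aromatic ring of carbon only, para to a large group; seen one bond further out, a phenyl becomes a 4-chlorophenyl.

Among the compounds with values here, no pair of measured compounds here differs by exactly this change, so there is no measured step to lean on. The expectation rests on compound 2 alone and on the modest size of the change, a single chlorine added to an aromatic ring. The expected step from compound 2 to compound 4 is small, a 1.0-fold higher number from compound 2 to compound 4 (0.01 log units; within the scatter), with neither direction favored beyond the scatter. Compound 4 is accordingly estimated at 100 nM, with a likely range from 40 nM to 250 nM.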

Compound 4, dissociation constant: 77.6 nM
Beside the measured number, compound 4's estimate is 1.3-fold (0.11 log units) above it; measured number inside the range.
By their numbers in this assay, from the lowest: compounds 4 and 2 (each within the scatter of the next); then compounds 1 and 3 (each within the scatter of the next).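

In this assay, within the data shown here, the step reads a 1.3-fold lower number from compound 2 to compound 4 (0.10 log units; within the scatter) and so gives the first measured look at this position. Chloro in place of hydrogen, on an aromatic carbon para to a large group, leaves compound 2 and compound 4 within the scatter of each other, which shows that this phenyl can become a 4-chlorophenyl, gaining one heavy atom, with no change in the number that this assay can resolve. Nothing measured here explains why the number holds.

A single chloro cannot show whether this position accepts other groups in general, so a fluoro, a bromo, a trifluoromethyl, an amine or a carboxylic acid at the same place might behave quite differently. Also open, from the compounds shown here alone, is whether chloro would give a similar result on another aromatic carbon of this ring, or on the longer chain of compound 1, since a single step from compound 2 cannot be carried over to a different position or a different chain.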